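The source may report more compounds than this note shows. Statements on the series, on what has been measured and on what is new or still open speak of the compounds shown alone.

Measured so far in a functional assay on A549 cells (Homo sapiens) for antiproliferative activity, read by MTT assay, with a stated time of 24 h; a lower number here means a stronger inhibitor, a higher number a weaker inhibitor: compound 1 `COc1cc(C2CC(c3ccc(Cl)cc3)=NN2c2ccc(-c3ccccc3)nn2)cc(OC)c1OC` gives 83300 nM; compound 2 `COc1ccc(C2=NN(c3ccc(-c4ccccc4)nn3)C(c3ccccc3)C2)cc1` gives 75900 nM. Compound 3 `COc1ccc(C2=NN(c3ccc(-c4ccccc4)nn3)C(c3ccc(C(F)(F)F)cc3)C2)cc1` reaches only the upper limit of this assay, > 100000 nM.

Compound 3 therefore stands at a limit, not a number; among the three values shown, (the limit of > 100000 nM in this assay, at which 1 of the 3 values shown sits). Compound 4 `COc1ccc(C2=NN(c3ccc(-c4ccccc4)nn3)C(c3cc(OC)c(OC)c(OC)c3)C2)cc1` differs from compound 3 by 3,4,5-trimethoxyphenyl in place of 4-(trifluoromethyl)phenyl on a saturated ring carbon. For the measured compounds named here, the only measured step at this saturated ring carbon is an at least 1.3-fold higher number from compound 2 to compound 3 (0.11 log units; that floor lies within the scatter), a small move that says little about a trimethoxyphenyl. Going by the values given here, compound 1, which carries the same trimethoxyphenyl on that carbon beside a different aryl, gives 83300 nM; no step to compound 4 is available, so its value is only a hint. Compound 4 is expected near 80000 nM, within 30000 nM to 200000 nM. That estimate implies an at least 1.2-fold lower number from compound 3 to compound 4 (0.09 log units; that floor lies within the scatter), with a fair chance of another limit.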

Compound 4, half-maximal inhibitory concentration: > 100000 nM
Compound 4: no number, only a limit; the forecaster's own chance of this, stated with the estimate: 40%; middle value at least 1.2-fold (0.09 log units) away from the limit.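

In this assay, 3,4,5-trimethoxyphenyl in place of phenyl on the saturated ring carbon gives an at least 1.3-fold higher number from compound 2 to compound 4 (0.11 log units; that floor lies within the scatter), and methoxy in place of chloro on an aromatic carbon gives an at least 1.2-fold higher number from compound 1 to compound 4 (0.07 log units; that floor lies within the scatter). Compound 4 stands at a limit of the assay, > 100000 nM. The step between compound 3 and compound 4 cannot be read, and a second, quite different aryl group at this carbon ends at the same limit: the limit of > 100000 nM in this assay, at which 2 of the 4 values shown sit.

Still open, from the compounds shown here alone, is whether any change at this carbon gives a step beyond the scatter. An amine or a carboxylic acid on this aryl ring, or a longer chain in its place, would test that.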